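A few compounds are considered here, and "the series" means these few. Any claim that something is new, unique, unknown or untested is made for them only; others in the source may bear on it.

Working notes on the series. Four compounds share one core: compound 1 `CC1CC(=O)c2s/c(=N/c3ccccc3)oc2C1`, compound 2 `CC(C)C1CC(=O)c2s/c(=N/c3ccccc3)oc2C1` and compound 3 `CC1(C)CC(=O)c2s/c(=N/c3ccc(Cl)cc3)oc2C1` have been measured, compound 4 `CC(C)C1CC(=O)c2s/c(=N/c3ccc(F)cc3)oc2C1` has not. In a functional assay on HCT-15 cells (Homo sapiens) for antiproliferative activity, read by sulforhodamine B assay (a lower number here means a stronger inhibitor of growth, a higher number a weaker inhibitor of growth), compound 1 gives 2070 nM, compound 2 gives 1150 nM and compound 3 gives 3790 nM. Compound 2 lies within the scatter of compound 1, as the step of a 1.8-fold lower number from compound 1 to compound 2 (0.26 log units; within the scatter) shows, and beyond it from compound 3; compound 3 differs from compound 2 in two places, so only the two numbers themselves can be set side by side. Compound 4 carries fluoro in place of hydrogen on an aromatic carbon. Among the measured compounds shown here, no measured step alters the aromatic ring alone, and the step of a 1.8-fold lower number from compound 1 to compound 2 (0.26 log units; within the scatter) concerns the saturated ring, so it does not bear on this change. For compound 4 the expected step is a 1.3-fold higher number from compound 2 to compound 4 (0.12 log units; within the scatter). Compound 4 is therefore estimated at 1500 nM, with a range of 600 nM to 3800 nM.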

Compound 4, concentration for 50% growth inhibition: 2990 nM
Estimate against measurement, compound 4: 2.0-fold (0.30 log units) below; measured number inside the range.
By their numbers in this assay, from the lowest: compounds 2, 1, 4 and 3 (each within the scatter of the next, the first and the last beyond it).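

In this assay, among the compounds shown here, fluoro in place of hydrogen on an aromatic carbon gives a 2.6-fold higher number from compound 2 to compound 4 (0.41 log units; beyond the scatter) and is the first measured change to the aromatic ring alone. This position, para to a large group, is therefore not silent: a single fluorine moves the number beyond the scatter, and the move is towards weaker growth inhibition. No measurement in hand accounts for this step. From the compounds shown here alone, whether methoxy or an amine at this place shifts the number in the same direction remains open. Also open, going by these compounds, is whether the fluoro step holds with methyl in place of isopropyl on the saturated ring.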